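Methoxy for Trifluoromethyl on a Xanthine-Pyrazole Series

The source may report more compounds than this note shows. Statements on the series, on what has been measured and on what is new or still open speak of the compounds shown alone.

Measured compounds:
- Compound 1 `CCn1c(=O)c2nc(-c3cnn(Cc4cccc(F)c4)c3)[nH]c2n(CC)c1=O`: 380 nM
- Compound 2 `CCCn1c(=O)c2nc(-c3cnn(Cc4ccccc4C(F)(F)F)c3)[nH]c2n(CCC)c1=O`: 44 nM
- Compound 3 `CCn1c(=O)c2nc(-c3cnn(Cc4ccccc4)c3)[nH]c2n(CC)c1=O`: 580 nM

In an assay on CHO cells for displacement of a labelled ligand from adenosine receptor A1 (Homo sapiens) (on this read-out higher numbers stand for weaker inhibition and lower numbers for stronger inhibition), compound 2 gives the lowest number of the three. Among the measured compounds shown here, compound 1 gives 380 nM and compound 3 gives 580 nM in this assay, and both of these gaps to compound 2 lie beyond the scatter; compound 2 differs from each of them in more than one place, so no single step is drawn from those pairs.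

The unmeasured compound 4 `CCCn1c(=O)c2nc(-c3cnn(Cc4ccccc4OC)c3)[nH]c2n(CCC)c1=O` is reached from compound 2 by one change: methoxy in place of trifluoromethyl on an aromatic carbon

For the measured compounds named here, the only measured step that touches a substituent on this same benzyl ring is a 1.5-fold higher number from compound 1 to compound 3 (0.18 log units; within the scatter), and it stays within the scatter. That step swaps a different group at a different place on the ring, so it says little about an exchange of trifluoromethyl for methoxy ortho to a large group. With no closer guide, compound 4 is expected to stay near compound 2, with a step of a 1.8-fold higher number from compound 2 to compound 4 (0.26 log units; within the scatter) that may well fall within the scatter. The estimate for compound 4 in this assay is 80 nM, with a range from 30 nM to 250 nM.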

Compound 4, inhibition constant: 59 nM
The estimate for compound 4 lay 1.4-fold (0.13 log units) above the measured number, and the stated range covers the measured number.
By their numbers in this assay, from the lowest: compounds 2 and 4 (each within the scatter of the next); then compounds 1 and 3 (each within the scatter of the next).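

In this assay, the exchange of trifluoromethyl for methoxy on an aromatic carbon ortho to a large group gives a 1.3-fold higher number from compound 2 to compound 4 (0.13 log units; within the scatter), so this read-out does not separate the 2-(trifluoromethyl)benzyl and 2-methoxybenzyl compounds. Among the compounds shown here, the earlier compounds offered only a hydrogen-for-fluoro step on a different core, whereas this pair gives the first direct reading at this place, and it holds even though the entering group has fewer heavy atoms, carries oxygen instead of fluorine and adds a hydrogen-bond acceptor. No measurement accompanies this result that could explain why the two compounds read alike.

The compounds shown leave open how an amine, a carboxylic acid or plain hydrogen at this place would read on the core of compound 2. As far as these compounds go, it also remains open whether the same exchange would read alike on the core of compound 3, and how much of the gap between compound 2 and compounds 1 and 3 belongs to the chains on the core rather than to the benzyl ring.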